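Urea series: from compound 2 to compound 4

The compounds below may be only part of what the source reports. "The series", "measured", "known", "first", "only" and "open" are said of these compounds alone.

compound 1 `CC1CN(C(=O)c2ccc(-c3ccc(NC(=O)Nc4ccc(Cl)c(C(F)(F)F)c4)cc3)cc2)CC(C)O1` gives 2050 nM
compound 2 `O=C(/C=C/c1ccc(NC(=O)Nc2ccc(Cl)c(C(F)(F)F)c2)cc1)NC1CCC1` gives 4430 nM
compound 3 `CC(NC(=O)C#Cc1ccc(NC(=O)Nc2ccc(Cl)c(C(F)(F)F)c2)cc1)c1ccccc1` gives 4920 nM

In a functional assay on HT-29 cells (Homo sapiens) for inhibition, read by MTT assay, with a stated time of 120 h (on this read-out lower numbers stand for stronger inhibition and higher numbers for weaker inhibition), compound 2 at 4430 nM stands with compound 3 at 4920 nM at the upper end of the three numbers, the two within the scatter of each other, while compound 1 lies lower, beyond the scatter of compound 2. Compound 4 `CNC(=O)CCc1ccc(NC(=O)Nc2ccc(Cl)c(C(F)(F)F)c2)cc1` is not yet measured. It differs from compound 2 by 2-(methylcarbamoyl)ethyl in place of 2-(cyclobutylcarbamoyl)ethenyl on an aromatic carbon on an aromatic carbon, para to a large group, with 2-(methylcarbamoyl)ethyl in place of 2-(cyclobutylcarbamoyl)ethenyl. Within the data shown here, no measured pair differs in one place, so the data give no direct size for this change. A small step toward weaker inhibition is expected, with a 1.7-fold higher number from compound 2 to compound 4 (0.23 log units; within the scatter) as the estimate for now. For compound 4 the estimated value is 7500 nM and 2500 nM to 20000 nM is the expected range.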

Compound 4, half-maximal inhibitory concentration: 20600 nM
For compound 4 the middle estimate is 2.7-fold (0.44 log units) below the measured one, and the stated range ends below it.
By their numbers in this assay, from the lowest: compound 1; then compounds 2 and 3 (each within the scatter of the next); then compound 4.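

In this assay, among these compounds, 2-(methylcarbamoyl)ethyl in place of 2-(cyclobutylcarbamoyl)ethenyl on an aromatic carbon, para to a large group, gives a 4.7-fold higher number from compound 2 to compound 4 (0.67 log units; beyond the scatter) and is the only step that can be sized. The read-out at this position therefore responds to the group placed there, although the change removes the four-membered ring and a double bond together. No measured property bears on the reason for this step. Still open, as far as these compounds go, is which of the two changes carries the step, and how an amine or a carboxylic acid at this position would read.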